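Removing a Hydroxy Group from a Weakly Cytotoxic Scaffold

The source may hold more compounds than are shown below. What is called first, only, known or untested is meant among the compounds shown, and "the series" means these compounds.

Compound 1, `COc1cc(N2C(N)=C(C#N)C(/C=C/c3ccccc3)C3=C2CC(C)(C)CC3=O)cc(OC)c1OC`, gives 10% in a functional assay on Ehrlich cells (Mus musculus) for cytotoxicity, tested at 10 ug/mL; on this read-out higher numbers stand for a stronger effect at the one concentration tested and lower numbers for a weaker effect.
Compound 2, `COc1cc(N2C(N)=C(C#N)C(c3ccccc3O)C3=C2CC(C)(C)CC3=O)cc(OC)c1OC`, gives 0% in this assay.

Within the data shown here, compound 2 holds the smaller of the two numbers, but the only measured step, a number 10 percentage points lower from compound 1 to compound 2 (within the scatter), falls within the scatter, so the two compounds cannot be told apart on these data. Both sit near the floor of the read-out.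

Compound 3, `COc1cc(N2C(N)=C(C#N)C(c3ccccc3)C3=C2CC(C)(C)CC3=O)cc(OC)c1OC`, differs from compound 2 by hydrogen in place of hydroxy on an aromatic carbon. Among the measured compounds shown here, no measured step follows this particular change; the one step known swaps a whole side group and is itself within the scatter. The two values seen so far are both low, and nothing in them points to a move in either direction, so no step beyond the scatter is expected in this assay.

Compound 3 is therefore estimated at 5%, with a range of 0% to 20%, which means an expected step of a number 5 percentage points higher from compound 2 to compound 3 (within the scatter).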

Compound 3, a percentage reported as activity, at one concentration (the size of the read-out at that concentration, not a potency): 0%
For compound 3 the middle estimate is 5 percentage points above the measured one; low and high end bracket the measured number.
By their numbers in this assay, from the lowest: compounds 2, 3 and 1 (each within the scatter of the next).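

Replacing the hydroxy group with hydrogen brings no change at the digits printed from compound 2 to compound 3 (within the scatter) in this assay and so gives no sign that this read-out depends on that hydroxy group. Phenyl in place of 2-phenylethenyl on the saturated ring carbon brings a number 10 percentage points lower from compound 1 to compound 3 (within the scatter) and adds a third side group at this position that cannot be told apart from the other two. Nothing available explains this flat result.

All three compounds sit close to the bottom of the read-out, so a change that would weaken the effect could hardly show here. From the compounds shown here alone, whether an amine or a carboxylic acid in place of the hydroxy group, or a longer chain on the saturated ring carbon, would lift the number stays open.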